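A Nitrophenyl Swap at the Saturated Ring Carbon

This account rests on a few compounds, and the source may have more. Where it says the series, first, only, none or still open, it means among the compounds named here.

Among the measured compounds shown here, compound 2 `CC1(C)CC(=O)C2=C(C1)NC(c1ccccc1)=CC2c1ccco1` is the one member of this small set with a numerical result. In an assay on isolated protein for inhibition of glucose-6-phosphatase catalytic subunit 1 (Homo sapiens), read by inositol phosphate accumulation, with a stated time of 30 min, tested at 100 uM (a lower number here means less inhibition, a higher number more inhibition at the concentration tested (going by the name of the read-out)), compound 2 gives 11.4%. Compound 1 `CCOC(=O)C1(O)CC(c2ccc(Cl)cc2)C2=C(CC(C)(C)CC2=O)O1` was reported in this assay as "not active" (no number reported), a reading without a number, so it cannot serve as a second anchor. For the measured compounds named here, no step between two measured compounds is available to show how any single change moves the read-out. Going by the values given here, the only footing for compound 3 `CC1(C)CC(=O)C2=C(C1)NC(c1ccccc1)=CC2c1ccc([N+](=O)[O-])cc1` is therefore the reading of compound 2. Compound 3 differs from compound 2 by one change: 4-nitrophenyl in place of furan-2-yl on a saturated ring carbon. Among the compounds with values here, since no measured pair shows what such a swap does in this assay, the expected step is one that stays within the usual scatter, in no firm direction: a number 0.6 percentage points higher from compound 2 to compound 3 (within the scatter). Compound 3 is thus estimated at 12% in this assay, with a range from 0% to 30%.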

Compound 3, a percentage reported as inhibition, at one concentration (the size of the read-out at that concentration, not a potency): "not active" (no number reported)
The entry for compound 3 holds no number; there is nothing to compare the estimate with.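

In this assay, among the compounds shown here, compound 3 is reported without a number, so no step between compound 2 and compound 3 can be read. The compounds shown leave open whether 4-nitrophenyl in place of furan-2-yl moves the read-out at all. No evidence shown bears on this result.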